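The compounds below may be only part of what the source reports. "The series", "measured", "known", "first", "only" and "open" are said of these compounds alone.

Measured in a functional assay on HeLa cells (Homo sapiens) for antiproliferative activity, read by MTT assay, with a stated time of 72 h; a lower number here means a stronger inhibitor, a higher number a weaker inhibitor:

- Compound 1 `O=C1COc2ccc(-c3cnc(Cl)c(NS(=O)(=O)c4ccc(F)cc4)c3)cc2N1C1CCCCC1`: 14300 nM
- Compound 2 `COc1ccc(N2C(=O)COc3ccc(-c4ccc(O)cc4)cc32)cc1`: 16400 nM
- Compound 3 `COc1cccc(N2C(=O)COc3ccc(-c4cccc(NS(=O)(=O)c5ccc(F)cc5)c4)cc32)c1`: > 40000 nM, a limit and not a number

Compound 3 has no number of its own in this assay, only a limit: the limit of > 40000 nM in this assay, at which 1 of the 3 values shown sits.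

The next compound to be tested is compound 4 `O=C1COc2ccc(-c3cccc(NS(=O)(=O)c4ccc(F)cc4)c3)cc2N1C1CC1`, which differs from compound 3 in one place, with cyclopropyl in place of 3-methoxyphenyl on an amide-type nitrogen in a ring.

Among the measured compounds shown here, no measured pair differs in a single place, so the size of this step cannot be read directly from the data. The expectation rests on compound 1, at 14300 nM, which also carries a non-aromatic carbon ring on that nitrogen, although it differs from compound 4 elsewhere as well. This is weak support, and a result at the limit of this assay would be no surprise.

The expected step, an at least 1.6-fold lower number from compound 3 to compound 4 (0.20 log units; that floor lies within the scatter), is a modest one towards a stronger inhibitor.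

Compound 4 is estimated at 25000 nM, with an expected range of 10000 nM to 60000 nM.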

Compound 4, half-maximal inhibitory concentration: > 40000 nM
Compound 4: only a limit was reported; the forecaster's own chance of this, stated with the estimate: 35%; middle value at least 1.6-fold (0.20 log units) away from the limit.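

In this assay compound 4 gives > 40000 nM, a limit and not a number. Among the compounds shown here, compound 3 also stands only at a limit, so no step between compound 3 and compound 4 can be read: the limit of > 40000 nM in this assay, at which 2 of the 4 values shown sit. The compounds shown leave open how cyclopropyl compares with 3-methoxyphenyl on this amide-type nitrogen.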